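The source may hold more compounds than are shown below. What is called first, only, known or untested is meant among the compounds shown, and "the series" means these compounds.

The shared core is carried unchanged through compound 1 `CC(=O)Nc1ccc(-n2nncc2CN2C(=O)C3(C(C#N)=C(N)Oc4c(N)cc5nc6ccccc6nc5c43)c3ccccc32)cc1`, compound 2 `CCOc1ccc(-n2nncc2CN2C(=O)C3(C(C#N)=C(N)Oc4c(N)cc5nc6ccccc6nc5c43)c3ccccc32)cc1` and compound 3 `CCOc1ccccc1-n1nncc1CN1C(=O)C2(C(C#N)=C(N)Oc3c(N)cc4nc5ccccc5nc4c32)c2ccccc21`. In a functional assay on MCF7 cells (Homo sapiens) for antiproliferative activity, read by MTT assay, with a stated time of 48 h (on this read-out lower numbers stand for stronger inhibition and higher numbers for weaker inhibition), compound 2 gives 26800 nM. Compound 1 gives only a limit, > 50000 nM. Compound 3 likewise reaches only a limit, > 50000 nM, so compound 3 sits at the limit of > 50000 nM in this assay, at which 2 of the 3 values shown sit, with one further value beside it also a limit. The step of an at least 1.8-fold higher number from compound 2 to compound 3 (0.27 log units; that floor lies within the scatter) is a floor, and a step that the two limits leave unreadable from compound 1 to compound 3 is not readable. Compound 4 `COc1ccc(OC)c(-n2nncc2CN2C(=O)C3(C(C#N)=C(N)Oc4c(N)cc5nc6ccccc6nc5c43)c3ccccc32)c1` differs from compound 3 by 2,5-dimethoxyphenyl in place of 2-ethoxyphenyl on an aromatic nitrogen. Going by the values given here, no measured step changes this ring in the same way, so the step of a number no higher from compound 3 to compound 4 (the limit leaves the size open) is expected to stay near zero. Compound 4 is estimated at 50000 nM, within 20000 nM to 120000 nM, likely again only a limit.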

Compound 4, half-maximal inhibitory concentration: 28100 nM
For compound 4 the middle estimate is 1.8-fold (0.25 log units) above the measured one; measured number inside the range.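

In this assay, 2,5-dimethoxyphenyl on the aromatic nitrogen gives a measurable number where 2-ethoxyphenyl does not, with an at least 1.7-fold lower number from compound 3 to compound 4 (0.25 log units; that floor lies within the scatter). The same holds against 4-acetamidophenyl, with an at least 1.7-fold lower number from compound 1 to compound 4 (0.25 log units; that floor lies within the scatter), while a 1.0-fold higher number from compound 2 to compound 4 (0.02 log units; within the scatter) leaves 2,5-dimethoxyphenyl and 4-ethoxyphenyl indistinguishable at this position. Compound 3 remains only a limit: the limit of > 50000 nM in this assay, at which 2 of the 4 values shown sit.

Compound 4 swaps ethoxy for methoxy and adds a second methoxy at once, and the two changes cannot be separated here. From the compounds shown here alone, whether an amine or a longer chain such as butoxy on this phenyl ring would move the number beyond the scatter remains open.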